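A few compounds are considered here, and "the series" means these few. Any claim that something is new, unique, unknown or untested is made for them only; others in the source may bear on it.

In a functional assay on HeLa cells (Homo sapiens) for inhibition, read by MTT assay, with a stated time of 72 h (on this read-out lower numbers stand for stronger inhibition and higher numbers for weaker inhibition), compound 3 `CC(C)(C)Oc1ccc(-c2nnc(SCCCN3CCN(c4nc5ccccc5s4)CC3)o2)cc1` gives 217000 nM. This is within the scatter of compound 2 `Cc1ccc(-c2nnc(SCCCN3CCN(c4nc5ccccc5s4)CC3)o2)cc1` at 179000 nM, and both numbers are higher than that of compound 1 `O=C(NCc1nnc(SCCCN2CCN(c3nc4ccccc4o3)CC2)o1)c1ccccc1` at 63900 nM. Compound 4 `O=C(NCc1nnc(SCCCN2CCN(c3nc4ccccc4s3)CC2)o1)c1ccccc1` has benzamidomethyl in place of 4-(tert-butoxy)phenyl on an aromatic carbon. Within the data shown here, the only measured step, a 1.2-fold higher number from compound 2 to compound 3 (0.08 log units; within the scatter), stays within the scatter but does not involve benzamidomethyl. The closest guide is compound 1, which carries benzamidomethyl on a core that is not identical and gives 63900 nM. A lower number in this assay is therefore expected, with the estimated step being a 2.3-fold lower number from compound 3 to compound 4 (0.36 log units; beyond the scatter). Compound 4 is estimated at 95000 nM, with an expected range of 40000 nM to 200000 nM.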

Compound 4, half-maximal inhibitory concentration: 78100 nM
Estimate against measurement, compound 4: 1.2-fold (0.09 log units) above, within the range that was stated.
By their numbers in this assay, from the lowest: compounds 1 and 4 (each within the scatter of the next); then compounds 2 and 3 (each within the scatter of the next).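

At this position on the shared core, benzamidomethyl gives lower numbers than either aryl group in this assay: a 2.8-fold lower number from compound 3 to compound 4 (0.44 log units; beyond the scatter) and a 2.3-fold lower number from compound 2 to compound 4 (0.36 log units; beyond the scatter), both modest. With benzamidomethyl present, 1,3-benzothiazol-2-yl in place of 1,3-benzoxazol-2-yl on the ring amine nitrogen stays within the scatter, a 1.2-fold higher number from compound 1 to compound 4 (0.09 log units; within the scatter). No measured evidence bears on the origin of these steps. Still open, as far as these compounds go, is how a carboxylic acid or a primary amine at this position would read, and whether a longer chain in benzamidomethyl would keep the lower number.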